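One More Chain Carbon: From Compound 2 to Compound 4

This account rests on a few compounds, and the source may have more. Where it says the series, first, only, none or still open, it means among the compounds named here.

Compound 1 `CCCCNCC(=O)Nc1ccc(/C(N)=N/O)cc1`: 83000 nM
Compound 2 `CCCCCCNCCCC(=O)Nc1ccc(/C(N)=N/O)cc1`: 312000 nM
Compound 3 `CCCCCCNC(=O)Nc1ccc(/C(N)=N/O)cc1`: 195000 nM

In a functional assay on HCT-116 cells (Homo sapiens) for antiproliferative activity, read by WST assay, with a stated time of 72 h (a higher number here means that more compound is needed for the effect, a lower number that less compound is needed), compound 2 gives the highest of the three numbers. Its gap to compound 3 lies within the scatter, whereas compound 1 sits clearly lower, beyond the scatter. Compound 4 `CCCCCCNCCCCC(=O)Nc1ccc(/C(N)=N/O)cc1` differs from compound 2 by (hexylamino)methyl in place of hexylamino on a saturated chain carbon, three bonds along the chain from a carbonyl carbon. Among the compounds with values here, no pair of measured compounds isolates a change of this kind, so the expectation leans only on compound 1 and compound 2, where the compound carrying the longer chain gives the higher number. The step is therefore expected to be small, upward if anything, and not beyond the scatter. For compound 4 in this assay the estimate is 350000 nM, ranging from 150000 nM to 800000 nM. This corresponds to an expected step of a 1.1-fold higher number from compound 2 to compound 4 (0.05 log units; within the scatter).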

Compound 4, half-maximal effective concentration: > 1000000 nM
Compound 4: a limit, no number; the forecaster's own chance of this, stated with the estimate: 15%; middle value at least 2.8-fold (0.45 log units) away from the limit.
By their numbers in this assay, from the lowest: compound 1; then compounds 3 and 2 (each within the scatter of the next). At a limit, above all of these: compound 4.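

The change to (hexylamino)methyl on a saturated chain carbon, three bonds along the chain from a carbonyl carbon, gives an at least 3.2-fold higher number from compound 2 to compound 4 (0.50 log units; beyond the scatter) in this assay as the only single-place step shown. Compound 4 gives > 1000000 nM as a limit of the assay and not a number. Within the data shown here, this position therefore responds to one more chain carbon, something compounds 1, 2 and 3 could not show, as no pair among them differs in one place.

On these data alone, whether a shorter chain here would lower the number remains open. So does the effect of a carboxylic acid in place of the hexylamino end.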